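The source may report more compounds than this note shows. Statements on the series, on what has been measured and on what is new or still open speak of the compounds shown alone.

In a functional assay on KG-1 cells (Homo sapiens) for cytotoxicity, read by luminescence and CellTiter-Glo, with a stated time of 3 days (a lower number here means a stronger inhibitor, a higher number a weaker inhibitor), three compounds have been measured so far. Compound 1 (`N#Cc1ccc(NC(=O)c2cc(-c3ccccc3)ccc2O)cc1`) gives 1300 nM, compound 2 (`O=C(Nc1ccc(C(F)(F)F)cc1)c1cc(Cl)ccc1O`) gives 740 nM, and compound 3 (`N#Cc1ccc(NC(=O)c2cc(F)ccc2O)cc1`) gives 2670 nM, the highest number of the three.

The change under review leads to compound 4 (`O=C(Nc1ccc(C(F)(F)F)cc1)c1cc(F)ccc1O`), with trifluoromethyl in place of cyano on an aromatic carbon, para to a large group: trifluoromethyl in place of cyano on an aromatic carbon.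

Among the measured compounds shown here, no measured step isolates this exchange. For the measured compounds named here, the only single-place step, a 2.1-fold higher number from compound 1 to compound 3 (0.31 log units; beyond the scatter), is fluoro in place of phenyl. Going by the values given here, it concerns a different group and indicates only that a modest step can be resolved. The closer evidence comes from compound 2, which carries trifluoromethyl and gives 740 nM, while compound 3 gives 2670 nM. On these data alone, these two compounds also differ at a second place, so only part of that gap can be assigned to the exchange, and the split is unknown.

A modest step towards a lower number is therefore expected in this assay, though one that stays within the scatter cannot be ruled out. The estimated step is a 2.1-fold lower number from compound 3 to compound 4 (0.31 log units; beyond the scatter). Compound 4 is expected at 1300 nM, with an estimated range of 600 nM to 2800 nM.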

Compound 4, half-maximal inhibitory concentration: 1700 nM
Compound 4: the middle estimate sits 1.3-fold (0.12 log units) below what was measured; the measured number falls inside the stated range.
By their numbers in this assay, from the lowest: compounds 2, 1, 4 and 3 (each within the scatter of the next, the first and the last beyond it).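

In this assay, trifluoromethyl in place of cyano on an aromatic carbon, para to a large group, now has a direct reading: a 1.6-fold lower number from compound 3 to compound 4 (0.20 log units; within the scatter). On this reading, compounds 3 and 4 cannot be told apart, so this single exchange does not resolve in the series at this point, with fluoro held on the shared core. With trifluoromethyl held constant, fluoro in place of chloro gives a 2.3-fold higher number from compound 2 to compound 4 (0.36 log units; beyond the scatter), the first single-place step showing that exchanging these two halogens can be resolved, though there is no measurement here that explains either step.

Among the compounds shown here, it remains open whether the exchange of cyano for trifluoromethyl would read the same with chloro or phenyl on the core in place of fluoro, since the only direct reading carries fluoro. On these data alone, it is also open whether an amine or a carboxylic acid on the aromatic carbon that carries cyano or trifluoromethyl would give a step beyond the scatter, or whether these compounds mark the range of what that place allows.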